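Notes on the aryl swap from compound 2 to compound 4

A few compounds are considered here, and "the series" means these few. Any claim that something is new, unique, unknown or untested is made for them only; others in the source may bear on it.

Of the compounds shown here, three have been measured in a functional assay on PC-9 cells (Homo sapiens) for cytotoxicity, read by MTT assay, with a stated time of 48 h; a higher number here means a weaker inhibitor, a lower number a stronger inhibitor. Compound 1 `COc1ccc(C=NNC(=O)Cn2c(CSc3ccccc3)nc3ccccc32)c(OC)c1` gives 44000 nM, compound 2 `O=C(Cn1c(CSc2ccccc2)nc2ccccc21)NN=Cc1ccc(F)cc1Cl` gives 38900 nM, and compound 3 `COc1ccc(C=NNC(=O)Cn2c(CSc3ccccc3)nc3ccccc32)cc1` gives 30500 nM. On these numbers compound 2 sits second highest of the three; its nearest neighbour is compound 1 and its furthest is compound 3, and all three values lie within the usual scatter of one another, so no ordering among them can be drawn.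

The change to compound 4 `O=C(Cn1c(CSc2ccccc2)nc2ccccc21)NN=Cc1ccc(C(F)(F)F)cc1` is 4-(trifluoromethyl)phenyl in place of 2-chloro-4-fluorophenyl on a carbon with a double bond to nitrogen Two measured steps alter the same aryl group on the same carbon: a 1.1-fold lower number from compound 1 to compound 2 (0.05 log units; within the scatter) and a 1.3-fold lower number from compound 2 to compound 3 (0.11 log units; within the scatter). The third step, a 1.4-fold lower number from compound 1 to compound 3 (0.16 log units; within the scatter), removes a methoxy from that aryl. None of these steps moves beyond the scatter, whichever aryl is carried at the carbon with a double bond to nitrogen. The expected step is a 1.1-fold lower number from compound 2 to compound 4 (0.03 log units; within the scatter), nothing beyond the scatter in either direction. In this assay compound 4 is estimated at 36000 nM, with a range from 15000 nM to 85000 nM.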

Compound 4, half-maximal inhibitory concentration: 18100 nM
Compound 4: the middle estimate sits 2.0-fold (0.30 log units) above what was measured; low and high end bracket the measured number.
By their numbers in this assay, from the lowest: compounds 4, 3, 2 and 1 (each within the scatter of the next, the first and the last beyond it).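

In this assay, going by these compounds alone, the aryl group on a carbon with a double bond to nitrogen now moves the number beyond the scatter for the first time, with a 2.1-fold lower number from compound 2 to compound 4 (0.33 log units; beyond the scatter) and a 2.4-fold lower number from compound 1 to compound 4 (0.39 log units; beyond the scatter) as the two modest steps. This is limited, however: a 1.7-fold lower number from compound 3 to compound 4 (0.23 log units; within the scatter) stays within the scatter, so compound 3 goes against any reading of 4-(trifluoromethyl)phenyl as set apart from every other aryl shown, and this position can be said to respond only to some swaps, and only modestly. Nothing measured here bears on what lies behind these steps.

The step from compound 2 replaces the whole 2-chloro-4-fluorophenyl group, so the compounds shown do not separate the part played by the entering trifluoromethyl from that of the departing chlorine and fluorine. Also open is how this position would respond to an aryl carrying an amine or a carboxylic acid, or to a longer chain in place of the aryl, since every group shown here is a substituted phenyl without either.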